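Phenyl to propyl: stepping beyond the measured pair

This account rests on a few compounds, and the source may have more. Where it says the series, first, only, none or still open, it means among the compounds named here.

Two stereoisomers open the set. Compound 1 `CN1O[C@@H](n2cc(-c3ccccc3)nn2)C[C@@H]1CO` and compound 2 `CN1O[C@H](n2cc(-c3ccccc3)nn2)C[C@@H]1CO` share every atom and bond and differ only in configuration as drawn. In a functional assay on FTC-133 cells (Homo sapiens) for cytotoxicity, read by MTT assay, with a stated time of 24 h (a higher number here means a weaker inhibitor, a lower number a stronger inhibitor), compound 1 gives 6030 nM, and compound 2 gives 6330 nM. The step of a 1.0-fold higher number from compound 1 to compound 2 (0.02 log units; within the scatter) shows that the fact that compounds 1 and 2 differ only in the configuration as drawn leaves the number within the scatter. Among the two numbers measured, compound 2 stands highest, with compound 1 as its nearest neighbour, the gap within the scatter.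

Compound 3 `CCCc1cn([C@@H]2C[C@H](CO)N(C)O2)nn1` is not yet measured. It differs from compound 2 by propyl in place of phenyl on an aromatic carbon. Going by the values given here, no measured step touches this change; the only known step concerns configuration and gives no guide to exchanging one group for another on the ring. The expected step of a 1.4-fold higher number from compound 2 to compound 3 (0.15 log units; within the scatter) is therefore small and carries a wide range. Compound 3 is estimated in this assay at 9000 nM, between 2500 nM and 35000 nM.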

Compound 3, half-maximal inhibitory concentration: 4710 nM
The estimate for compound 3 lay 1.9-fold (0.28 log units) above the measured number; low and high end bracket the measured number.
By their numbers in this assay, from the lowest: compounds 3, 1 and 2 (each within the scatter of the next).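

In this assay, going by these compounds alone, propyl in place of phenyl on the aromatic carbon gives a 1.3-fold lower number from compound 2 to compound 3 (0.13 log units; within the scatter) and is the first change of a group rather than of configuration. At this position of the five-membered aromatic ring with 3 nitrogen, a chain with no ring and 3 heavy atoms thus gives a number within the scatter of that from the six-membered aromatic ring with 6 heavy atoms, so the aromatic ring is not needed to keep the number in this range. No available observation bears on this exchange of groups.

On these data alone, whether a longer chain, an amine or a carboxylic acid at this position would also stay within the scatter remains open. So does whether propyl would give the same result with the configuration of compound 1.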